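The source may hold more compounds than are shown below. What is called first, only, known or untested is meant among the compounds shown, and "the series" means these compounds.

Measured compounds in an assay on isolated protein for displacement of a labelled ligand from 5-hydroxytryptamine receptor 6 (Homo sapiens); a higher number here means a weaker inhibitor, a lower number a stronger inhibitor:
compound 1 `CNS(=O)(=O)NC[C@@H]1CCCc2cc(S(=O)(=O)c3cccc(F)c3)ccc21` gives 1 nM
compound 2 `CN(C)S(=O)(=O)NC[C@@H]1CCCc2cc(S(=O)(=O)c3cccc(F)c3)ccc21` gives 2 nM
compound 3 `O=S(=O)(c1cccc(F)c1)c1ccc2c(c1)CCC[C@H]2CN1CC(O)C1` gives 0.1 nM

Compound 3 stands lowest of the three in this assay. Its nearest neighbour is compound 1, separated by a 10-fold lower number from compound 1 to compound 3 (1.00 log units; beyond the scatter); compound 2 lies furthest, separated by a 20-fold lower number from compound 2 to compound 3 (1.30 log units; beyond the scatter). Between the two sulfamide-bearing analogues the step is a 2.0-fold higher number from compound 1 to compound 2 (0.30 log units; within the scatter).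

Compound 4 `N=C(N)NC(=O)C[C@@H]1CCCc2cc(S(=O)(=O)c3cccc(F)c3)ccc21` is not yet measured. Relative to compound 3 the change is a group of 6 heavy atoms (2 carbon, 3 nitrogen, 1 oxygen; no ring) in place of a group of 5 heavy atoms (3 carbon, 1 nitrogen, 1 oxygen; one four-membered non-aromatic ring with 1 hetero atom), on a saturated chain carbon bound to a saturated ring carbon.

Within the data shown here, two measured steps bear on this change. Both steps toward compound 3 exchange a chain group at this carbon for the 3-hydroxyazetidin-1-yl ring, giving a 10-fold lower number from compound 1 to compound 3 (1.00 log units; beyond the scatter) and a 20-fold lower number from compound 2 to compound 3 (1.30 log units; beyond the scatter). The step to compound 4 runs the other way: the ring leaves and a chain group enters. The entering group is neither (methylsulfamoyl)amino nor (dimethylsulfamoyl)amino, so the size of the reversal is uncertain, but a higher number in this assay is expected, of the order seen between compound 3 and compound 1 or compound 2. Compound 4 is therefore estimated at 2 nM, within 0.5 nM to 10 nM. As a step this estimate means a 20-fold higher number from compound 3 to compound 4 (1.30 log units; beyond the scatter) is expected.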

Compound 4, inhibition constant: 0.631 nM
Estimate against measurement, compound 4: 3.2-fold (0.50 log units) above; the range from low to high includes it.
By their numbers in this assay, from the lowest: compound 3; then compounds 4, 1 and 2 (each within the scatter of the next, the first and the last beyond it).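

In this assay, the sulfur-free open-chain group of compound 4 cannot be told apart from the sulfamide of compound 1 (a 1.6-fold lower number from compound 1 to compound 4 (0.20 log units; within the scatter)), yet it stands clear of the dimethylated sulfamide (a 3.2-fold lower number from compound 2 to compound 4 (0.50 log units; beyond the scatter)), so a sulfamide is not needed at this saturated chain carbon to reach this range. The 3-hydroxyazetidin-1-yl ring still keeps its lead over a third open-chain group (a 6.3-fold higher number from compound 3 to compound 4 (0.80 log units; beyond the scatter)), and among the compounds shown, no open-chain group goes against that pattern. No measurement at hand accounts for these differences.

The compounds shown leave open whether the low number of compound 3 goes with the four-membered ring or with its hydroxyl, a question that a plain azetidin-1-yl group or an open-chain dimethylamino group would help to settle. Also open, from the compounds shown here alone, is which part of the group in compound 4 sets its number, which a simple primary amide or a guanidine without the carbonyl at the same carbon would begin to separate.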